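The compounds below may be only part of what the source reports. "The series", "measured", "known", "first", "only" and "open" are said of these compounds alone.

Measured compounds:
compound 1, `COc1cc(C)cc(-c2c(-c3ccnc(-c4ccc(C(C)=O)cc4)c3)cnn2CC#N)c1`: in a functional assay on COLO 205 cells (Homo sapiens) for inhibition, read by sulforhodamine B assay, with a stated time of 48 h (on this read-out lower numbers stand for stronger inhibition of growth and higher numbers for weaker inhibition of growth), compound 1 gives 3700 nM
compound 2, `Cc1cc(O)cc(-c2nn(CC#N)cc2-c2ccnc(-c3ccc(Oc4ccccc4)cc3)c2)c1`: in this assay compound 2 gives 3260 nM
compound 3, `COc1cc(C)cc(-c2nn(CC#N)cc2-c2ccnc(-c3ccc(N(C)C)cc3)c2)c1`: in this assay compound 3 gives 7690 nM

Compound 3 stands at the highest number of the three and is thus the weakest growth inhibitor of the set; compound 1 comes nearest, with a gap beyond the usual scatter, and compound 2 lies furthest, also beyond the scatter. The three compounds differ from one another in more than one place, so no single structural step can be read off from them.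

Compound 4, `Cc1cc(O)cc(-c2nn(CC#N)cc2-c2ccnc(-c3ccc(N(C)C)cc3)c2)c1`, is not yet measured. It differs from compound 3 only in hydrogen in place of methyl on an oxygen on an aromatic ring; the rest of the molecule is kept. Among the compounds with values here, no measured pair shows this change in isolation: compound 2 carries the hydroxy but a different distal group, and compound 1 carries the methoxy with yet another, so their values say nothing clean about the swap. The expectation is therefore a step from compound 3 to compound 4 of a 1.4-fold lower number from compound 3 to compound 4 (0.15 log units; within the scatter), toward a lower number if anything, most likely within the scatter. For compound 4 the estimate in this assay is 5500 nM, with a range from 2000 nM to 15000 nM.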

Compound 4, concentration for total growth inhibition: 4130 nM
Beside the measured number, compound 4's estimate is 1.3-fold (0.12 log units) above it; the range from low to high includes it.
By their numbers in this assay, from the lowest: compounds 2, 1, 4 and 3 (each within the scatter of the next, the first and the last beyond it).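

In this assay, the methoxy to hydroxy change now stands alone, with the dimethylamino group kept, and gives a 1.9-fold lower number from compound 3 to compound 4 (0.27 log units; within the scatter); at this place on the 3-hydroxy-5-methylphenyl group, hydrogen in place of methyl on the oxygen therefore leaves the pair inside the usual scatter. Within the data shown here, the second change can also be read in isolation for the first time, with the hydroxy kept: dimethylamino in place of phenoxy on an aromatic carbon gives a 1.3-fold higher number from compound 2 to compound 4 (0.10 log units; within the scatter), so these two groups are not told apart on this read-out, even though they differ widely in name and size of substituent. No supporting data bear on the size of either step.

Still open, from the compounds shown here alone, is whether the methoxy to hydroxy change gives a similar step when phenoxy, or the group carried by compound 1, replaces dimethylamino. Also open, going by these compounds, is whether an ethoxy or an amino group at the oxygen-bearing place, or a carboxylic acid or a morpholine in place of dimethylamino, would move the number beyond the scatter.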